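Moving the hydroxy and adding bromine in compound 3

This account rests on a few compounds, and the source may have more. Where it says the series, first, only, none or still open, it means among the compounds named here.

Among the compounds with values here, in a functional assay on BGC-823 cells (Homo sapiens) for cytotoxicity, read by MTT assay, with a stated time of 48 h (on this read-out higher numbers stand for weaker inhibition and lower numbers for stronger inhibition), compound 1 `O=C(CSc1nnc(-c2ccncc2)o1)N/N=C/c1ccc(F)cc1` gives 17800 nM, while compound 2 `O=C(CSc1nnc(-c2ccncc2)o1)N/N=C/c1ccc(O)cc1` gives 7940 nM, the lowest of the two numbers known; that shift was a 2.2-fold lower number from compound 1 to compound 2 (0.35 log units; beyond the scatter). Compound 3 `O=C(CSc1nnc(-c2ccncc2)o1)N/N=C/c1cc(Br)ccc1O` differs from compound 2 by 5-bromo-2-hydroxyphenyl in place of 4-hydroxyphenyl on a carbon with a double bond to nitrogen. Within the data shown here, no measured step covers adding bromine or shifting the hydroxy; the only step known, fluoro to hydroxy, was modest, so nothing points strongly either way. The step is therefore expected to be small: a 1.3-fold lower number from compound 2 to compound 3 (0.12 log units; within the scatter). Compound 3 is estimated at 6000 nM, with a range from 2000 nM to 20000 nM.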

Compound 3, half-maximal inhibitory concentration: 9590 nM
Estimate against measurement, compound 3: 1.6-fold (0.20 log units) below; measured number inside the range.
By their numbers in this assay, from the lowest: compounds 2, 3 and 1 (each within the scatter of the next, the first and the last beyond it).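

Placing 5-bromo-2-hydroxyphenyl where 4-hydroxyphenyl stood gives a 1.2-fold higher number from compound 2 to compound 3 (0.08 log units; within the scatter) in this assay and so leaves the number unchanged within the usual scatter, which shows that this position tolerates the larger group. Set against 4-fluorophenyl, the same group gives a 1.9-fold lower number from compound 1 to compound 3 (0.27 log units; within the scatter) and so cannot be separated from it, although the hydroxy of compound 2 could. Nothing measured here explains these results. As far as these compounds go, compound 3 carries the bromine and the moved hydroxy together, so the share of each stays open. From the compounds shown here alone, whether an amine or a carboxylic acid on this ring would give a clearer step also stays open.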